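Replacing the Benzyl Substituent: Cytotoxicity of Compound 4

A few compounds are considered here, and "the series" means these few. Any claim that something is new, unique, unknown or untested is made for them only; others in the source may bear on it.

Measured compounds:
Compound 1, `CCOC(=O)c1cnc(N2CCN(Cc3cccc(Br)c3)CC2)nc1Oc1c(C)cc(-c2ccc(C#N)cc2)cc1C`, in an ADME assay on MT4 cells (Homo sapiens) for cytotoxicity, read by MTT assay, with a stated time of 4 days (a lower number here means that less compound is tolerated, a higher number that more compound is tolerated), gives > 125000 nM; this is a limit of the assay, not a number.
Compound 2, `CCOC(=O)c1cnc(N2CCN(Cc3ccc([N+](=O)[O-])cc3)CC2)nc1Oc1c(C)cc(-c2ccc(C#N)cc2)cc1C`, in this assay gives > 125000 nM; again a limit.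
Compound 3, `CCOC(=O)c1cnc(N2CCN(Cc3ccc(S(C)(=O)=O)cc3)CC2)nc1Oc1c(C)cc(-c2ccc(C#N)cc2)cc1C`, in this assay gives > 125000 nM; again a limit.

All three compounds share the same core and differ only in the group on the benzyl piece. Compound 3 stands at the same limit as the other two, so no ordering among them can be read. The steps a step that the two limits leave unreadable from compound 1 to compound 2, a step that the two limits leave unreadable from compound 1 to compound 3 and a step that the two limits leave unreadable from compound 2 to compound 3 carry no readable size because of the limit of > 125000 nM in this assay, at which 3 of the 3 values shown sit.

Compound 4, `CCOC(=O)c1ccc(CN2CCN(c3ncc(C(=O)OCC)c(Oc4c(C)cc(-c5ccc(C#N)cc5)cc4C)n3)CC2)cc1`, differs from compound 3 by ethoxycarbonyl in place of methylsulfonyl on an aromatic carbon. For the measured compounds named here, none of the measured steps gives a size for this kind of change, since every one of them rests on two limits. The only expectation that the data support is that compound 4 also lies at the limit. Compound 4 is therefore expected to give 150000 nM, within 60000 nM to 400000 nM. This estimate corresponds to a step that the limit leaves unreadable from compound 3 to compound 4, nothing beyond the scatter.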

Compound 4, half-maximal cytotoxic concentration: > 125000 nM
Compound 4 gave a limit, no number (the forecaster's own chance of this, stated with the estimate: 80%); the middle value lies beyond the limit too.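

Compound 4 stands at the same limit as compound 1, compound 2 and compound 3, so none of its steps to them can be read: the limit of > 125000 nM in this assay, at which 4 of the 4 values shown sit.

The compounds shown leave open whether any of the four truly differ in this assay, and which benzyl substituent, if any, would give a readable number.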